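Swapping Hydroxy for Nitro in Compound 1

The source may report more compounds than this note shows. Statements on the series, on what has been measured and on what is new or still open speak of the compounds shown alone.

In a functional assay on SNU-638 cells (Homo sapiens) for cytotoxicity, read by MTT assay (on this read-out lower numbers stand for stronger inhibition and higher numbers for weaker inhibition), compound 1 `O=C(/C=C/c1ccc(N2CCCC2)cc1)c1ccc(O)cc1` gives 620 nM, the lower of the two numbers available, while compound 2 `O=C(/C=C/c1ccc(F)cc1)c1ccc(O)cc1` gives 5540 nM. Compound 3 `O=C(/C=C/c1ccc(N2CCCC2)cc1)c1ccc([N+](=O)[O-])cc1` keeps the pyrrolidin-1-yl group of compound 1 and has nitro in place of hydroxy on an aromatic carbon, para to a large group: nitro in place of hydroxy on an aromatic carbon. Going by the values given here, the only measured step, an 8.9-fold higher number from compound 1 to compound 2 (0.95 log units; beyond the scatter), is modest but beyond the scatter. It puts fluoro in place of pyrrolidin-1-yl and leaves the hydroxy untouched, so it bears on the new change only indirectly, as a guide to size. No measurement tests the hydroxy itself. A step of similar or smaller size is therefore expected, leaning towards a higher number, though the direction is uncertain. The estimate is an expected 2.1-fold higher number from compound 1 to compound 3 (0.32 log units; beyond the scatter). For compound 3 the estimated value is 1300 nM, with an expected range of 300 nM to 6000 nM.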

Compound 3, half-maximal inhibitory concentration: > 25000 nM
Compound 3: a limit, no number; the forecaster's own chance of this, stated with the estimate: 5%; middle value at least 19-fold (1.28 log units) away from the limit.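

In this assay, going by these compounds alone, nitro in place of hydroxy, with the pyrrolidin-1-yl group kept, gives an at least 40-fold higher number from compound 1 to compound 3 (1.60 log units; beyond the scatter), a large step at a place on the core that the earlier compounds left untouched. The value of compound 3, > 25000 nM, is a limit and not a number, and the full size of the step cannot be read from it: the limit of > 25000 nM in this assay, at which 1 of the 3 values shown sits. This place is thus not indifferent to change, and the step here is larger than the modest one for fluoro in place of pyrrolidin-1-yl, an 8.9-fold higher number from compound 1 to compound 2 (0.95 log units; beyond the scatter).

The compounds shown do not separate the loss of hydroxy from the arrival of nitro, a question on which an amine or a methoxy group at this place would bear. Going by these compounds, whether the change acts alike when fluoro replaces pyrrolidin-1-yl also stays open.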